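The source may hold more compounds than are shown below. What is called first, only, known or untested is meant among the compounds shown, and "the series" means these compounds.

Three analogues with a shared core have been measured in a functional assay on A549 cells (Homo sapiens) for antiproliferative activity, read by MTT assay, with a stated time of 72 h; a higher number here means a weaker inhibitor, a lower number a stronger inhibitor. Compound 1 `O=C(Nc1ccc(Oc2ccnc3[nH]ccc23)c(F)c1)c1cc2cccnc2n(-c2ccc(F)cc2)c1=O` gives 62 nM, compound 2 `Cn1ccc2c(Oc3ccc(NC(=O)c4cc5cccnc5n(-c5ccc(F)cc5)c4=O)cc3)ccnc21` gives 210 nM, and compound 3 `Cn1ccc2c(Oc3ccc(NC(=O)c4cc5cccnc5n(-c5ccccc5)c4=O)cc3F)ccnc21` gives 430 nM. Compound 3 therefore stands highest of the three numbers: its nearest neighbour is compound 2, whose number is lower by an amount beyond the scatter, and the furthest is compound 1, lower still by a margin well beyond the scatter. Within the data shown here, no single-change step between measured compounds is available, so the pairs can only be compared as whole values.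

Compound 4 `Cn1ccc2c(Oc3ccc(NC(=O)c4cc5cccnc5n(-c5ccc(F)cc5)c4=O)cc3F)ccnc21` is the next structure in line. It differs from compound 3 by fluoro in place of hydrogen on an aromatic carbon, which, read one bond further out, turns a phenyl into a 4-fluorophenyl. Compound 2 also carries a 4-fluorophenyl, and compound 1 carries both that group and the fluoro on the central ring, yet neither pair forms a listed step, so only their whole values speak.

The expected step in this assay from compound 3 to compound 4 is a 1.7-fold lower number from compound 3 to compound 4 (0.24 log units; within the scatter), a modest move toward a lower number, possibly within the scatter. Compound 4 is estimated at 250 nM, with a range from 100 nM to 600 nM.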

Compound 4, half-maximal inhibitory concentration: 280 nM
Beside the measured number, compound 4's estimate is 1.1-fold (0.05 log units) below it; the measured number falls inside the stated range.
By their numbers in this assay, from the lowest: compound 1; then compounds 2, 4 and 3 (each within the scatter of the next, the first and the last beyond it).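

In this assay, the two fluoro changes can now be read as single steps, and neither lies beyond the scatter: a 1.5-fold lower number from compound 3 to compound 4 (0.19 log units; within the scatter) for phenyl to 4-fluorophenyl, and a 1.3-fold higher number from compound 2 to compound 4 (0.12 log units; within the scatter) for fluoro at a different aromatic carbon. Among these compounds, the only step here beyond the scatter is methyl in place of hydrogen on an aromatic nitrogen, a 4.5-fold higher number from compound 1 to compound 4 (0.65 log units; beyond the scatter). Among these compounds, then, the larger gap belongs to the change at that nitrogen rather than to either fluoro change, and nothing shown here accounts for any of these steps.

As far as these compounds go, it remains open whether a chloro or methoxy group in place of the fluoro on the 4-fluorophenyl would give a step beyond the scatter. From the compounds shown here alone, it is also open how an ethyl group on the aromatic nitrogen would compare with the methyl.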